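This account rests on a few compounds, and the source may have more. Where it says the series, first, only, none or still open, it means among the compounds named here.

Compound 2, with structure `CN1CCN(C23CC(NC(=O)CCN4CCCCC4)C(C(c4ccccc4)C2)C(c2ccccc2)C3)CC1`, gives 15400 nM in an ADME assay on L6 cells (Rattus norvegicus) for cytotoxicity, read by fluorescence, with a stated time of 72 h (on this read-out higher numbers stand for weaker inhibition and lower numbers for stronger inhibition), which is the lowest of the three numbers recorded. Compound 1, `CN1CCN(C23CCN(CCCN4CCCCC4)C(C(c4ccccc4)C2)C(c2ccccc2)C3)CC1`, gives 28900 nM in this assay, a gap from compound 2 that lies within the scatter; compound 3, `CN1CCN(C23CCN(CCCN4CCCC4)C(C(c4ccccc4)C2)C(c2ccccc2)C3)CC1`, gives 43500 nM, a gap that lies beyond it.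

The unmeasured compound 4 has structure `CN1CCN(C23CC(NCCCN4CCCC4)C(C(c4ccccc4)C2)C(c2ccccc2)C3)CC1`. It differs from compound 2 in one place: 3-(pyrrolidin-1-yl)propyl in place of (2-(piperidin-1-yl)ethyl)carbonyl on an amine nitrogen. Two things change there at once, the loss of the carbonyl and the swap of the six-membered ring for the five-membered one.

Among the measured compounds shown here, only one measured step bears on it directly. The swap of ring size alone, a 1.5-fold higher number from compound 1 to compound 3 (0.18 log units; within the scatter), stayed within the scatter. For the measured compounds named here, for the loss of the carbonyl no single-change step exists; compound 2 and compound 1 differ in more than one place, and their numbers differ only within the scatter. The ring-size step points, if anywhere, toward a higher number, and compound 1 and compound 3 both sit above compound 2.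

Compound 4 is therefore expected to give 32000 nM in this assay, with a range of 14000 nM to 75000 nM. This estimate means a step of a 2.1-fold higher number from compound 2 to compound 4 (0.32 log units; beyond the scatter), expected to be modest in size and toward weaker inhibition.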

Compound 4, half-maximal inhibitory concentration: 22600 nM
For compound 4 the middle estimate is 1.4-fold (0.15 log units) above the measured one; the measured number falls inside the stated range.
By their numbers in this assay, from the lowest: compounds 2, 4, 1 and 3 (each within the scatter of the next, the first and the last beyond it).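

In this assay, replacing (2-(piperidin-1-yl)ethyl)carbonyl with 3-(pyrrolidin-1-yl)propyl on the amine nitrogen gives a 1.5-fold higher number from compound 2 to compound 4 (0.17 log units; within the scatter) and so stays within the scatter, even though the carbonyl and the six-membered ring leave together. Among the compounds shown here, the only earlier single-place step, a 1.5-fold higher number from compound 1 to compound 3 (0.18 log units; within the scatter) in this assay, changed the ring size alone at a different place on the shared core, so it said nothing about this amine nitrogen or about the carbonyl. Nothing available here explains why this double change leaves the number within the scatter.

What the compounds shown leave open is how the step divides between its two parts, with neither 3-(piperidin-1-yl)propyl nor (2-(pyrrolidin-1-yl)ethyl)carbonyl on this amine nitrogen to separate the loss of the carbonyl from the change of ring. Also open, on these data alone, is whether a morpholine at the end of the chain, a simple dimethylamino group there, or a longer chain on the same nitrogen would move the number in this cytotoxicity read-out beyond the scatter.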